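Benzyl to allyl swap on a protected pyranose core

A few compounds are considered here, and "the series" means these few. Any claim that something is new, unique, unknown or untested is made for them only; others in the source may bear on it.

Values in a functional assay on HeLa cells (Homo sapiens) for antiproliferative activity, read by sulforhodamine B assay; a lower number here means a stronger inhibitor of growth, a higher number a weaker inhibitor of growth:
Compound 1 `C=CC[C@@H]1O[C@H](COCc2ccccc2)[C@@H](OCc2ccccc2)[C@H](OCc2ccccc2)[C@H]1O`: 26200 nM
Compound 2 `O[C@@H]1[C@@H](OCc2ccccc2)[C@H](OCc2ccccc2)[C@@H](COCc2ccccc2)O[C@H]1Cc1ccccc1`: 17400 nM
Compound 3 `O=C1[C@H](Cc2ccccc2)O[C@H](COCc2ccccc2)[C@@H](OCc2ccccc2)[C@@H]1OCc1ccccc1`: only a limit, > 50000 nM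

Compound 2 and compound 1 differ by vinyl in place of phenyl on a saturated chain carbon bound to a saturated ring carbon, and this gave a 1.5-fold higher number from compound 2 to compound 1 (0.18 log units; within the scatter). Compound 3 carries a carbonyl on the core instead of the hydroxyl of compound 2; the difference between the two cores is not broken down here. Compound 3 sits at the limit of > 50000 nM in this assay, at which 1 of the 3 values shown sits.

Compound 4 `C=CC[C@@H]1O[C@H](COCc2ccccc2)[C@@H](OCc2ccccc2)[C@H](OCc2ccccc2)C1=O` is not yet measured in this assay . It differs from compound 3 by vinyl in place of phenyl on a saturated chain carbon bound to a saturated ring carbon, the same change at the same place as the one already measured. Because compound 3 sits at the limit of > 50000 nM in this assay, at which 1 of the 3 values shown sits, and because the measured change gave only a 1.5-fold higher number from compound 2 to compound 1 (0.18 log units; within the scatter), compound 4 is expected to sit at the limit as well. The expected step is a step that the limit leaves unreadable from compound 3 to compound 4. Compound 4 is estimated at 75000 nM, between 40000 nM and 160000 nM.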

Compound 4, concentration for 50% growth inhibition: > 50000 nM
Compound 4 was reported as a limit; the forecaster's own chance of this, stated with the estimate: 75%; the middle value lies beyond the limit too.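

In this assay compound 4 gives > 50000 nM, a limit, and compound 3 also stands at a limit, so no step between them can be read: the limit of > 50000 nM in this assay, at which 2 of the 4 values shown sit.

The compounds shown leave open whether benzyl to allyl changes growth inhibition on the carbonyl core.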